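A few compounds are considered here, and "the series" means these few. Any claim that something is new, unique, unknown or untested is made for them only; others in the source may bear on it.

Compound 1 `CCCCC[Se]c1nc(NCc2ccc(SC)cc2)c2ccccc2n1` gives > 100000 nM in an ADME assay on 184B5 cells (Homo sapiens) for cytotoxicity, read by MTT assay, with a stated time of 72 h (on this read-out higher numbers stand for weaker inhibition of growth and lower numbers for stronger inhibition of growth), which is a limit of the assay rather than a number.
Compound 2 `CCCCC[Se]c1nc(NCc2ccccc2)c2ccccc2n1` gives > 100000 nM in this assay, also a limit.

Both values sit at the limit of > 100000 nM in this assay, at which 2 of the 2 values shown sit, so the step that the two limits leave unreadable from compound 1 to compound 2, hydrogen in place of methylsulfanyl on an aromatic carbon, cannot be sized. Compound 1 thus stands only at a limit, with no number of its own. Compound 3 `CSc1ccc(CNc2nc(SC)nc3ccccc23)cc1` differs from compound 1 by a group of 2 heavy atoms (1 carbon, 1 sulfur; no ring) in place of a group of 6 heavy atoms (5 carbon, 1 selenium; no ring), on an aromatic carbon. No measured step covers this change, and the single step shown is unreadable, so neither direction nor size can be drawn from the numbers. Compound 3 is expected to remain near the limit, estimated at 150000 nM (range 30000 nM to 600000 nM), an expected step that the limit leaves unreadable from compound 1 to compound 3.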

Compound 3, concentration for total growth inhibition: > 100000 nM
Compound 3 gave a limit, no number; the forecaster's own chance of this, stated with the estimate: 75%; the middle value is on the limit's open side.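

Among these compounds, compound 3, like compounds 1 and 2, gives only a limit, so no step between these compounds can be read: the limit of > 100000 nM in this assay, at which 3 of the 3 values shown sit. The compounds shown leave open whether these changes alter growth inhibition in this assay at all, and by how much.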